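Working notes: from compound 1 to compound 3

This account rests on a few compounds, and the source may have more. Where it says the series, first, only, none or still open, it means among the compounds named here.

- compound 1 `C=C(Br)C(=O)Nc1cccc(/C=C/C(=O)Nc2ccc(C)cc2)c1`: 190 nM
- compound 2 `C=C(Br)C(=O)Nc1cccc(/C=C/C(=O)NCc2ccc(C)cc2)c1`: 1300 nM

Within the data shown here, in a functional assay on SEM cells (Homo sapiens) for inhibition, read by MTT assay, with a stated time of 72 h (a higher number here means a weaker inhibitor, a lower number a stronger inhibitor), compound 1 (190 nM) holds the lower of the two numbers so far. Among the measured compounds shown here, the only measured step is a 6.8-fold higher number from compound 1 to compound 2 (0.84 log units; beyond the scatter) and it is beyond the scatter. That step puts 4-methylbenzyl in place of 4-methylphenyl on an amide-type nitrogen.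

Compound 3 `C=C(Br)C(=O)Nc1cccc(/C=C/C(=O)Nc2ccc(OC(F)(F)F)cc2)c1` has not yet been measured. It carries trifluoromethoxy in place of methyl on an aromatic carbon, para to a large group: trifluoromethoxy in place of methyl on an aromatic carbon.

The measured step leaves the methyl in place, so it bears only indirectly on this change. For the measured compounds named here, no measured pair exchanges that methyl for anything else. Going by the values given here, the step shows only that one change can move the number beyond the scatter. In this assay the expectation is therefore no step beyond the scatter, with no firm direction and a wide margin. The expected step is a 1.1-fold lower number from compound 1 to compound 3 (0.05 log units; within the scatter). For compound 3 the estimated value is 170 nM, with an expected range from 60 nM to 450 nM.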

Compound 3, half-maximal inhibitory concentration: 19300 nM
Compound 3: middle estimate off by 110-fold (2.06 log units), on the low side; measured number above the stated range.
By their numbers in this assay, from the lowest: compound 1; then compound 2; then compound 3.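

The position para to a large group, left untouched by the earlier pair, proves strongly sensitive in this assay: trifluoromethoxy in place of methyl gives a 100-fold higher number from compound 1 to compound 3 (2.01 log units; beyond the scatter) and so exceeds the change on the amide-type nitrogen, where 4-methylbenzyl in place of 4-methylphenyl gave a 6.8-fold higher number from compound 1 to compound 2 (0.84 log units; beyond the scatter) in the same assay. The aromatic substituent therefore matters at least as much as the amide-type nitrogen in this short series, and this single pair ties the weaker inhibition to an exchange of 1 heavy atom for 5 heavy atoms, with 1 hydrogen-bond acceptor entering where there was none. Among these compounds, no measurement at hand bears on why this exchange moves the number so far.

The compounds shown leave open whether the loss is specific to trifluoromethoxy or extends to other groups at this position, and a methoxy group, a chlorine atom or a plain hydrogen there would help separate these possibilities. Also open, from the compounds shown here alone, is whether the same exchange would give a step of similar size on the 4-methylbenzyl amide of compound 2.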